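Swapping an aryl piece for pyrimidin-2-yl on the ring nitrogen

The source may hold more compounds than are shown below. What is called first, only, known or untested is meant among the compounds shown, and "the series" means these compounds.

Compound 1 `Cc1ccc(N2CCN(C(=S)SCc3ccc4nc(N)nc(N)c4c3)CC2)c(C)c1` carries a 2,4-dimethylphenyl group on an amine nitrogen in a ring. In a functional assay on HT-29 cells (Homo sapiens) for antiproliferative activity, read by MTT assay, with a stated time of 72 h (on this read-out lower numbers stand for stronger inhibition and higher numbers for weaker inhibition), compound 1 gives 2970 nM, the lowest of the three numbers measured, with the other two within the scatter of it. Compound 2 `Nc1nc(N)c2cc(CSC(=S)N3CCN(c4ccc(Cl)c(Cl)c4)CC3)ccc2n1` gives 3480 nM in this assay, and compound 3 `Nc1nc(N)c2cc(CSC(=S)N3CCN(c4ccc(F)cc4F)CC3)ccc2n1` gives 5020 nM. The steps between them, a 1.2-fold higher number from compound 1 to compound 2 (0.07 log units; within the scatter), a 1.7-fold higher number from compound 1 to compound 3 (0.23 log units; within the scatter) and a 1.4-fold higher number from compound 2 to compound 3 (0.16 log units; within the scatter), show that trading one substituted aryl group for another on that nitrogen barely moved the read-out. Compound 4 `Nc1nc(N)c2cc(CSC(=S)N3CCN(c4ncccn4)CC3)ccc2n1` makes a change of a different kind: pyrimidin-2-yl in place of 2,4-dimethylphenyl on an amine nitrogen in a ring. Among the compounds with values here, no measured step covers a ring bearing nitrogen in this position, so the bearing of the earlier steps is only partial, and they argue for a modest effect. The number for compound 4 is therefore expected to sit near that of compound 1, with the step of a 1.3-fold higher number from compound 1 to compound 4 (0.13 log units; within the scatter) estimated as small. The estimate for compound 4 is 4000 nM, within a range from 1500 nM to 12000 nM.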

Compound 4, half-maximal inhibitory concentration: 4720 nM
The estimate for compound 4 lay 1.2-fold (0.07 log units) below the measured number; low and high end bracket the measured number.
By their numbers in this assay, from the lowest: compounds 1, 2, 4 and 3 (each within the scatter of the next).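

In this assay, pyrimidin-2-yl on the amine nitrogen in a ring stays within the scatter of all three aryl compounds, as the new steps show: a 1.6-fold higher number from compound 1 to compound 4 (0.20 log units; within the scatter) and a 1.4-fold higher number from compound 2 to compound 4 (0.13 log units; within the scatter) and a 1.1-fold lower number from compound 3 to compound 4 (0.03 log units; within the scatter) in this read-out. Within the data shown here, the earlier compounds showed only that one aromatic ring of carbon can replace another here, whereas compound 4 extends this to a ring with 2 hetero atoms and 2 hydrogen-bond acceptors, with no step beyond the scatter among the four compounds. Nothing in the available data explains why the read-out stays so flat at this position.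

All four groups on this nitrogen are six-membered aromatic rings. From the compounds shown here alone, what a cyclohexyl ring, a longer alkyl chain or a carboxylic acid would do at this position stays open.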